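The source may hold more compounds than are shown below. What is called first, only, known or untested is meant among the compounds shown, and "the series" means these compounds.

In an ADME assay on the whole organism (Rattus norvegicus, strain Sprague-Dawley) for pharmacokinetics, at a dose of 10 mg/kg by the oral route (on this read-out lower numbers stand for lower oral bioavailability and higher numbers for higher oral bioavailability), compound 1 (`CCC(CC)N(CCN(C)C(=O)CCC(=O)O)Cc1cccc(C(=O)Nc2sc3c(c2C(=O)c2cnn(-c4ccc(Cl)c(C(F)(F)F)c4)c2)CCC(C)(C)C3)c1`) gives 7.1% and compound 2 (`CCC(CC)N(CCN(C)C(=O)CCC(=O)NCCOCCOCCOCCO)Cc1cccc(C(=O)Nc2sc3c(c2C(=O)c2cnn(-c4ccc(Cl)c(C(F)(F)F)c4)c2)CCC(C)(C)C3)c1`) gives 0.2%. These two values lie within the usual scatter of each other, so compound 2 cannot be separated from compound 1. Compound 3 (`CCC(CC)N(CCN(C)C(=O)CCC(=O)NC(C)(C)C(=O)NCCN(C)C)Cc1cccc(C(=O)Nc2sc3c(c2C(=O)c2cnn(-c4ccc(Cl)c(C(F)(F)F)c4)c2)CCC(C)(C)C3)c1`) differs from compound 2 on an amide-type nitrogen: a group of 11 heavy atoms (8 carbon, 2 nitrogen, 1 oxygen; no ring) in place of a group of 12 heavy atoms (8 carbon, 4 oxygen; no ring), on an amide-type nitrogen. Among the compounds with values here, no measured pair shows the effect of such an exchange, so no shift beyond the scatter is expected in this assay. The expected step is a number 3.8 percentage points higher from compound 2 to compound 3 (within the scatter). In this assay, compound 3 is estimated at 4%, with an expected range of 0.5% to 14%.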

Compound 3, oral bioavailability in the Rattus norvegicus assay: 0.6%
Compound 3: middle estimate off by 3.4 percentage points, on the high side, within the range that was stated.
By their numbers in the Rattus norvegicus assay, from the lowest: compounds 2, 3 and 1 (each within the scatter of the next).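

In the Rattus norvegicus assay, the exchange on the amide-type nitrogen gives a number 0.4 percentage points higher from compound 2 to compound 3 (within the scatter), and (1-((2-(dimethylamino)ethyl)carbamoyl)-1-methylethyl)amino in place of hydroxy on the carbonyl carbon gives a number 6.5 percentage points lower from compound 1 to compound 3 (within the scatter), so neither change separates the compounds on oral bioavailability. In a physicochemical assay for solubility, in simulated intestinal fluid, at pH 5.1 (a lower number here means a less soluble compound, a higher number a more soluble compound), compound 2 gives > 384 ug/mL as a limit, not a number: the limit of > 384 ug/mL in the physicochemical assay, at which 1 of the 2 values shown sits. In the physicochemical assay, compound 3 gives > 434 ug/mL as a limit too, not a number: the limit of > 434 ug/mL in the physicochemical assay, at which 1 of the 2 values shown sits.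

The step between these two limits cannot be read. Going by these compounds, whether a primary amine or a longer chain on this amide-type nitrogen would shift oral bioavailability beyond the scatter remains open.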